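Compound 4: Trifluoromethoxy in Place of Chloro

The source may hold more compounds than are shown below. What is called first, only, known or untested is meant among the compounds shown, and "the series" means these compounds.

Three compounds have been measured in an ADME assay on Vero cells (Chlorocebus sabaeus) for cytotoxicity, read by MTT assay, with a stated time of 48 h; a lower number here means that less compound is tolerated, a higher number that more compound is tolerated:

Compound 1 `COc1ccc(C(C)(C)NC(=O)c2ccc([N+](=O)[O-])o2)cc1`: 82000 nM
Compound 2 `CC(C)(NC(=O)c1ccc([N+](=O)[O-])o1)c1ccc(OC(F)(F)F)cc1`: 70000 nM
Compound 3 `CC(C)(NC(=O)c1ccc([N+](=O)[O-])o1)c1ccc(COc2ccc(Cl)cc2)cc1`: 120000 nM

Compound 3 gives the highest of the three numbers, but its neighbours sit close: the step of a 1.5-fold higher number from compound 1 to compound 3 (0.17 log units; within the scatter) and the step of a 1.7-fold higher number from compound 2 to compound 3 (0.23 log units; within the scatter) both lie within the scatter, so no order among the three can be claimed. The unmeasured compound 4 `CC(C)(NC(=O)c1ccc([N+](=O)[O-])o1)c1ccc(COc2ccc(OC(F)(F)F)cc2)cc1` differs from compound 3 by a single change: trifluoromethoxy in place of chloro on an aromatic carbon.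

Among the compounds with values here, two measured steps bear on this change. The step of a 1.2-fold lower number from compound 1 to compound 2 (0.07 log units; within the scatter) exchanges a methyl for a trifluoromethyl on an oxygen and stays within the scatter. The step of a 1.7-fold higher number from compound 2 to compound 3 (0.23 log units; within the scatter) removes a trifluoromethoxy from the shared core and adds the (4-chlorophenoxy)methyl group, again within the scatter. Every step seen so far in this assay is within the scatter, and nothing among these compounds points to the trifluoromethoxy group moving the number in this assay in either direction.

Compound 4 is therefore expected to give 120000 nM in this assay, with a range from 60000 nM to 240000 nM, and the expected step of no change at the digits printed from compound 3 to compound 4 (within the scatter) is not one beyond the scatter.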

Compound 4, half-maximal cytotoxic concentration: 6700 nM
For compound 4 the middle estimate is 18-fold (1.25 log units) above the measured one; measured number outside the range, below it.
By their numbers in this assay, from the lowest: compound 4; then compounds 2, 1 and 3 (each within the scatter of the next).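

In this assay, trifluoromethoxy in place of chloro on an aromatic carbon, para to a large group, gives an 18-fold lower number from compound 3 to compound 4 (1.25 log units; beyond the scatter), the first step among these compounds that lies beyond the scatter, so less of compound 4 is tolerated than of compound 3. Within the data shown here, this shows that the number responds strongly to a change at this position, which the earlier steps, all within the scatter, gave no sign of. The step of a 1.2-fold lower number from compound 1 to compound 2 (0.07 log units; within the scatter) also ends in a trifluoromethoxy group, but at another place on the shared core, so the quiet result there does not carry over to this aromatic carbon, and nothing in the material shown accounts for the size of the new step.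

The compounds shown leave open whether the lower number is particular to trifluoromethoxy or would also appear with other groups on this carbon, such as methoxy, trifluoromethyl, a nitrile or an amine. They also leave open whether a carboxylic acid or a longer chain there would stay close to compound 3 at 120000 nM or fall toward compound 4 at 6700 nM.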